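Swapping the Aryl Ether on a Diterpenoid Lactone

The compounds below may be only part of what the source reports. "The series", "measured", "known", "first", "only" and "open" are said of these compounds alone.

Within the data shown here, compound 2 `C=C1CC[C@@H]2[C@](C)(CO)[C@H](O)CC[C@@]2(C)[C@@H]1C/C=C1/C(=O)OC[C@H]1Oc1c(Cl)cc(Cl)c2cccnc12` is the only compound here with a measured number. In an ADME assay on SNB-19 cells (Homo sapiens) for cytotoxicity, read by MTT assay, with a stated time of 24 h (on this read-out higher numbers stand for lower toxicity in this test and lower numbers for higher toxicity in this test), compound 2 gives 85200 nM. Compound 1 `C=C1CC[C@H]2[C@@](C)(CCC(=O)[C@@]2(C)COC(C)=O)[C@@H]1C/C=C1/C(=O)OC[C@H]1Oc1c(Cl)cc(Cl)c2cccnc12` reaches only a limit in this assay, reported as > 100000 nM, so compound 1 sits at the limit of > 100000 nM in this assay, at which 1 of the 2 values shown sits. Compound 3 `C=C1CC[C@@H]2[C@](C)(CO)[C@H](O)CC[C@@]2(C)[C@@H]1C/C=C1/C(=O)OC[C@H]1Oc1cccnc1[N+](=O)[O-]` has not yet been measured; it differs from compound 2 by 2-nitropyridin-3-yl in place of 5,7-dichloroquinolin-8-yl on an oxygen on a saturated carbon. Among the measured compounds shown here, no measured pair separates these two groups, so the step is expected to stay within the usual scatter, with no set direction. Compound 3 is expected to give about 90000 nM in this assay, somewhere between 40000 nM and 200000 nM. That estimate means a step of a 1.1-fold higher number from compound 2 to compound 3 (0.02 log units; within the scatter).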

Compound 3, half-maximal cytotoxic concentration: 67700 nM
For compound 3 the middle estimate is 1.3-fold (0.12 log units) above the measured one; the measured number falls inside the stated range.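

On the oxygen on a saturated carbon, 2-nitropyridin-3-yl can replace 5,7-dichloroquinolin-8-yl, a group with two aromatic rings and two chlorines, and this assay shows a 1.3-fold lower number from compound 2 to compound 3 (0.10 log units; within the scatter). Among these compounds, this is the only measured pair here that separates two groups at this position, and this test does not tell them apart. No measured property shown here bears on this step. Still open, going by these compounds, is whether a plain phenyl ring or a group carrying an amine on this oxygen would read any differently.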